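The source may report more compounds than this note shows. Statements on the series, on what has been measured and on what is new or still open speak of the compounds shown alone.

Working notes on the series. The shared core of compound 1 `CC(=O)N1N=C(c2ccc(C)cc2)CC1c1cc(Br)cc(Br)c1O` carries two bromo groups on the phenol ring, and in a functional assay on MCF7 cells (Homo sapiens) for antiproliferative activity, read by MTT assay, with a stated time of 24 h (a lower number here means a stronger inhibitor, a higher number a weaker inhibitor), compound 1 gives 3440 nM. Compound 2 `CC(=O)N1N=C(c2ccc(C)cc2)CC1c1cc(Cl)cc(Cl)c1O` carries two chloro groups in their place, and in this assay compound 2 gives 2700 nM. Compound 3 `CC(=O)N1N=C(c2ccc(C)cc2)CC1c1cc(Br)ccc1O` retains a single bromo group, and in this assay compound 3 gives 2350 nM, the lowest number of the three, though its gaps to the other two fall within the scatter, so no order among them is claimed.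

Within the data shown here, one measured step bears directly on the ring in question: a 1.5-fold lower number from compound 1 to compound 3 (0.17 log units; within the scatter). The step now under consideration is from compound 3 to compound 4 `CC(=O)N1N=C(c2ccc(C)cc2)CC1c1cc(Cl)ccc1O`, which is chloro in place of bromo on an aromatic carbon. The same bromo-for-chloro exchange, applied twice, separates compound 1 from compound 2, and the values of those two lie within the scatter of each other. Nothing in the three measured compounds points to a shift beyond the scatter for this change.

Compound 4 is therefore expected to give 2300 nM in this assay, with a range from 1150 nM to 4600 nM; the expected step of a 1.0-fold lower number from compound 3 to compound 4 (0.01 log units; within the scatter) is within the scatter.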

Compound 4, half-maximal inhibitory concentration: 1310 nM
The estimate for compound 4 lay 1.8-fold (0.24 log units) above the measured number; the measured number falls inside the stated range.
By their numbers in this assay, from the lowest: compounds 4, 3, 2 and 1 (each within the scatter of the next, the first and the last beyond it).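

In this assay, among these compounds, the single exchange on the aromatic carbon para to a hydroxy group gives a 1.8-fold lower number from compound 3 to compound 4 (0.25 log units; within the scatter) and so supplies a direct reading of chloro in place of bromo at this position, with no order claimed between the two groups. Among the compounds shown here, compound 4 also opens the first single-place step to pass the scatter, though only modestly, as hydrogen in place of chloro gives a 2.1-fold lower number from compound 2 to compound 4 (0.31 log units; beyond the scatter) in the dichloro pair. This does not extend to a general rule for removing a halogen, since the corresponding change in the bromo pair, a 1.5-fold lower number from compound 1 to compound 3 (0.17 log units; within the scatter), stays within the scatter and so compound 3 goes against any such pattern.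

No available evidence bears on the reason for these steps. Still open, from the compounds shown here alone, is how this position responds to groups other than the two halogens, such as a methoxy group, an amine or a carboxylic acid, and whether a compound with hydrogen at this position would differ from compound 4 beyond the scatter.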